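This account rests on a few compounds, and the source may have more. Where it says the series, first, only, none or still open, it means among the compounds named here.

Of the compounds shown here, three on a shared core have been measured in an assay on HEK293 cells for inhibition of Voltage-dependent N-type calcium channel subunit alpha-1B (Homo sapiens), read by fluorescence and calcium flux, with a stated time of 5 min; on this read-out lower numbers stand for stronger inhibition and higher numbers for weaker inhibition. Compound 1 `COc1ccccc1-n1nc([C@@H]2CCO[C@H](C(C)C)C2)cc1-c1ccc(Cl)cc1` gives 7 nM, compound 3 `COc1ccccc1-n1nc(C2=CC(C)(C)OC(C)(C)C2)cc1-c1ccc(Cl)cc1` gives 3 nM, and compound 2 `COc1ccccc1-n1nc(C2CC(C)(C)OC(C)(C)C2)cc1-c1ccc(C)nc1` gives 6 nM. Among the measured compounds shown here, only one pair differs in a single place, and that step, a 2.3-fold lower number from compound 1 to compound 3 (0.37 log units; beyond the scatter), touches the non-aromatic ring rather than the aromatic group. Compound 2 stands second highest of the three numbers; its gap to compound 1 is within the scatter, as is its gap to compound 3, so no order among them can be stated.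

Compound 4 `CCOc1ccc(-c2cc(C3CC(C)(C)OC(C)(C)C3)nn2-c2ccccc2OC)cn1` differs from compound 2 in one place: ethoxy in place of methyl on an aromatic carbon. For the measured compounds named here, no measured step bears directly on this change, since the one step available alters a different ring and is itself modest. Going by the values given here, compound 1 and compound 2 differ in more than one place, and their values show only that two different aromatic groups land at comparable numbers. With all three measured compounds sitting in a narrow band, compound 4 is expected to stay near compound 2, with a step of no change at the digits printed from compound 2 to compound 4 (within the scatter) and no direction beyond the scatter. Compound 4 is therefore estimated at 6 nM, in the range 2.5 nM to 15 nM.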

Compound 4, half-maximal inhibitory concentration: 5 nM
Compound 4: the middle estimate sits 1.2-fold (0.08 log units) above what was measured; the measured number falls inside the stated range.
By their numbers in this assay, from the lowest: compounds 3, 4, 2 and 1 (each within the scatter of the next, the first and the last beyond it).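

In this assay, the exchange of 6-methylpyridin-3-yl for 6-ethoxypyridin-3-yl gives a 1.2-fold lower number from compound 2 to compound 4 (0.08 log units; within the scatter), so at this place, on an aromatic carbon next to the ring nitrogen and para to a large group, the two groups cannot be told apart. Among the compounds shown here, the earlier compounds gave no reading of this position, as their only single-place step lay in the non-aromatic ring; this step now shows that a larger group carrying an oxygen, and counted as a hydrogen-bond acceptor, can replace methyl here with no change beyond the scatter. Nothing available explains why the number holds, and no measurement bears on how either group acts at this position.

With only methyl and ethoxy shown at this place, the limit of what it accepts stays open, and a single step gives no trend with group size. A longer chain such as butoxy, an amine or a carboxylic acid at the same carbon could show whether the number stays in this narrow band or moves beyond the scatter.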